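The source may hold more compounds than are shown below. What is called first, only, known or untested is meant among the compounds shown, and "the series" means these compounds.

Values measured so far in an ADME assay on microsomes from liver (Rattus norvegicus) for metabolic stability; on this read-out lower numbers stand for a shorter-lived compound and higher numbers for a longer-lived compound
- compound 1 `Cn1nc2c(=O)n(CC3(O)CCN(Cc4ccc(-c5ccco5)cc4Cl)CC3)cnc2c1-c1ccc(CNC=O)cc1` gives 0.55 h
- compound 2 `Cn1nc2c(=O)n(CC3(O)CCN(Cc4ccc(-c5ccco5)cc4Cl)CC3)cnc2c1-c1ccc(F)cc1` gives 0.75 h

Among the measured compounds shown here, compound 2 stands level with compound 1, the only other measured compound, within the scatter (a 1.4-fold higher number from compound 1 to compound 2 (0.13 log units; within the scatter)). The next step leads to compound 3 `Cn1nc2c(=O)n(CC3(O)CCN(Cc4ccc(-c5ccco5)cc4Cl)CC3)cnc2c1-c1ccc(CN)cc1` and changes one group (aminomethyl in place of fluoro on an aromatic carbon): aminomethyl in place of fluoro on an aromatic carbon, para to a large group. For the measured compounds named here, only one measured step bears on this change, the one that puts fluoro in place of (formylamino)methyl on an aromatic carbon, and it stayed within the scatter. Going by the values given here, no measured compound carries aminomethyl, so the evidence is indirect and the range has to stay wide. With that single step as the guide (a 1.4-fold higher number from compound 1 to compound 2 (0.13 log units; within the scatter)), no shift beyond the scatter is expected in this assay, and the data give no firm direction. The expected step is small (a 1.3-fold lower number from compound 2 to compound 3 (0.10 log units; within the scatter)) and is estimated to stay within the scatter. For compound 3 the estimated half-life is 0.6 h, with an expected range from 0.3 h to 1.2 h around that middle.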

Compound 3, half-life: 2.37 h
Compound 3: middle estimate off by 4.0-fold (0.60 log units), on the low side; the whole stated range lies below it.
By their numbers in this assay, from the lowest: compounds 1 and 2 (each within the scatter of the next); then compound 3.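

In this assay, the position on the aromatic carbon, para to a large group, now proves able to move the half-life: a 3.2-fold higher number from compound 2 to compound 3 (0.50 log units; beyond the scatter) for aminomethyl in place of fluoro, whereas the earlier change at this position stayed level (a 1.4-fold higher number from compound 1 to compound 2 (0.13 log units; within the scatter)). The formyl group on the amine nitrogen also counts, since hydrogen in its place gives a 4.3-fold higher number from compound 1 to compound 3 (0.63 log units; beyond the scatter) and so separates aminomethyl from (formylamino)methyl, a difference the first two compounds could not reveal. Among these three compounds, only aminomethyl stands apart, while fluoro and (formylamino)methyl remain level, and no accompanying measurement accounts for that separation.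

The compounds shown leave open whether the higher number in this assay needs the unsubstituted amine or also holds for dimethylaminomethyl, for a longer chain such as 2-aminoethyl, or for hydroxymethyl, which has oxygen in place of the nitrogen. They also leave open whether the step from fluoro to aminomethyl keeps its size when the rest of the molecule changes, as all three compounds share everything outside this one position.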